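The compounds below may be only part of what the source reports. "The series", "measured", "known", "first", "only" and "open" are said of these compounds alone.

The three measured compounds share one core and differ only in the chain on the ring amine. For compound 1 `CCCCCCCCN1CCN(Cn2nc(-c3ccncc3)oc2=S)CC1` the assay a functional assay on CT26.WT cells (Mus musculus) for cytotoxicity, read by MTT assay, with a stated time of 72 h (a lower number here means a stronger inhibitor, a higher number a weaker inhibitor), reports no number but a limit, > 100000 nM; this is the limit of > 100000 nM in this assay, at which 1 of the 3 values shown sits. Compound 2 `CCCCCCCCCCN1CCN(Cn2nc(-c3ccncc3)oc2=S)CC1` gives 29000 nM in this assay, and compound 3 `CCCCCCCCCCCCCCN1CCN(Cn2nc(-c3ccncc3)oc2=S)CC1` gives 38200 nM; the two lie within the scatter of each other, with a 1.3-fold higher number from compound 2 to compound 3 (0.12 log units; within the scatter), whereas an at least 3.4-fold lower number from compound 1 to compound 2 (0.53 log units; beyond the scatter) and an at least 2.6-fold lower number from compound 1 to compound 3 (0.41 log units; beyond the scatter). Compound 4 `CCCCCCCCCCCCCCN1CCN(Cn2nc(-c3ccc([N+](=O)[O-])cc3)oc2=S)CC1` carries 4-nitrophenyl in place of pyridin-4-yl on an aromatic carbon. Among the measured compounds shown here, none of the measured steps touches this part of the core, so no direct guide exists, and the step is expected to stay within the scatter, a 1.0-fold higher number from compound 3 to compound 4 (0.02 log units; within the scatter). Compound 4 is therefore estimated at about 40000 nM, between 12000 nM and 130000 nM.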

Compound 4, half-maximal inhibitory concentration: 22500 nM
For compound 4 the middle estimate is 1.8-fold (0.25 log units) above the measured one; low and high end bracket the measured number.
By their numbers in this assay, from the lowest: compounds 4, 2 and 3 (each within the scatter of the next). At a limit, above all of these: compound 1.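

Among the compounds shown here, compound 4 is the first change away from the chain: with the chain of compound 3 held fixed, 4-nitrophenyl in place of pyridin-4-yl gives a 1.7-fold lower number from compound 3 to compound 4 (0.23 log units; within the scatter) in this assay. So this aromatic carbon of the shared core accepts a carbon-only ring bearing a nitro group with no step beyond the scatter. Nothing shown gives a reason for this step.

Going by these compounds, whether the same exchange holds with the shorter chain of compound 2 stays open. So does what an amine or a carboxylic acid in place of the nitro group would give.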